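Series notes: removing the aryl ethyl group

The source may hold more compounds than are shown below. What is called first, only, known or untested is meant among the compounds shown, and "the series" means these compounds.

Two members of the series carry a measurement in a functional assay on A549 cells (Homo sapiens) for inhibition; a lower number here means a stronger inhibitor, a higher number a weaker inhibitor. Compound 1 `CC(C)c1ccc(N2C(=O)C=CC2OCC(F)(F)F)cc1` gives 9570 nM, and compound 2 `CCc1ccc(N2C(=O)C=CC2OCC(F)(F)F)cc1` gives 8090 nM. Within the data shown here, the only step between measured compounds, a 1.2-fold lower number from compound 1 to compound 2 (0.07 log units; within the scatter), is small. Compound 2 thus stands at the lowest of the two numbers, with compound 1 as its nearest neighbour and not separated from it beyond the scatter, so no order between the two can be claimed.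

Compound 3 `O=C1C=CC(OCC(F)(F)F)N1c1ccccc1` is not yet measured. It differs from compound 2 in one place: hydrogen in place of ethyl on an aromatic carbon. The step from compound 1 to compound 2 bears on this change, since it too removed carbon from the saturated chain attached to the aromatic carbon, and that step lay within the scatter. Among the measured compounds shown here, only this one step is available, and it concerns a methyl rather than an ethyl, so the inference rests on thin ground. On that basis no change beyond the scatter is expected for compound 3 in this assay, the estimated step being a 1.1-fold higher number from compound 2 to compound 3 (0.05 log units; within the scatter). Compound 3 is estimated at 9000 nM, with an expected range from 3000 nM to 30000 nM.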

Compound 3, half-maximal inhibitory concentration: 23400 nM
The estimate for compound 3 lay 2.6-fold (0.41 log units) below the measured number; the range from low to high includes it.
By their numbers in this assay, from the lowest: compounds 2 and 1 (each within the scatter of the next); then compound 3.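

In this assay, the position para to a large group on the six-membered aromatic ring of carbon only now gives a readable response: hydrogen in place of ethyl produces a 2.9-fold higher number from compound 2 to compound 3 (0.46 log units; beyond the scatter) and hydrogen in place of isopropyl produces a 2.4-fold higher number from compound 1 to compound 3 (0.39 log units; beyond the scatter) in the same direction. Isopropyl and ethyl could not be told apart in the earlier comparison, yet removing either group altogether raises the number beyond the scatter, so among these three compounds, having one of these saturated carbon groups at this position goes with a lower number than having hydrogen there. No measurement shown here accounts for this difference.

As far as these compounds go, it remains open whether a longer chain such as butyl would keep the number close to those of compound 1 and compound 2 or move it further. From the compounds shown here alone, it is equally open whether the lower numbers need a saturated carbon group at all, since a methoxy group, an amine or a carboxylic acid at this position could show a different result.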